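Naphthyl analogues of the chalcone series

This account rests on a few compounds, and the source may have more. Where it says the series, first, only, none or still open, it means among the compounds named here.

Measured so far:
compound 1 `Cc1cc(O)c(C(=O)/C=C/c2ccccc2)c(-c2ccc(Cl)cc2)c1C(=O)/C=C/c1ccccc1` gives 15000 nM
compound 2 `Cc1cc(O)c(C(=O)/C=C/c2ccccc2)c(-c2ccccc2)c1C(=O)/C=C/c1ccccc1` gives 10000 nM
compound 3 `Cc1cc(O)c(C(=O)/C=C/c2ccc3ccccc3c2)c(-c2ccc(Cl)cc2)c1C(=O)/C=C/c1ccc2ccccc2c1` gives "not active" (no number reported)

In a functional assay on MCF7 cells (Homo sapiens) for cytotoxicity, read by MTT assay, with a stated time of 24 h (on this read-out higher numbers stand for weaker inhibition and lower numbers for stronger inhibition), compound 1 gives 15000 nM and compound 2 gives 10000 nM; the change between them is hydrogen in place of chloro on an aromatic carbon, and it made a 1.5-fold lower number from compound 1 to compound 2 (0.18 log units; within the scatter). Compound 3 `Cc1cc(O)c(C(=O)/C=C/c2ccc3ccccc3c2)c(-c2ccc(Cl)cc2)c1C(=O)/C=C/c1ccc2ccccc2c1` is reported as "not active" (no number reported) in this assay, with no single number given. The difference between the core of compound 3 and the core of compound 1 is not broken down here.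

Compound 4 `Cc1cc(O)c(C(=O)/C=C/c2ccc3ccccc3c2)c(-c2ccccc2)c1C(=O)/C=C/c1ccc2ccccc2c1` has not been measured. It differs from compound 3 by hydrogen in place of chloro on an aromatic carbon, the same change as from compound 1 to compound 2. Because that earlier change gave a 1.5-fold lower number from compound 1 to compound 2 (0.18 log units; within the scatter), a similarly small step is expected from compound 3 to compound 4 in this assay. Compound 4 is therefore expected to stay at 40000 nM, estimated between 15000 nM and 120000 nM, and quite possibly to return no number at all.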

Compound 4, half-maximal inhibitory concentration: 31500 nM
The estimate for compound 4 lay 1.3-fold (0.10 log units) above the measured number; low and high end bracket the measured number.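

Compound 3 carries no number in this assay; the step to compound 4, at 31500 nM, cannot be read. As far as these compounds go, whether 4-chlorophenyl to phenyl has the same size on the core of compound 3 as on the core of compound 1 stays open. No supporting evidence bears on this result.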